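Fluoro on the 3-phenyl ring of the hydroxamate series

The source may report more compounds than this note shows. Statements on the series, on what has been measured and on what is new or still open speak of the compounds shown alone.

Measured so far in a functional assay on MCF7 cells (Homo sapiens) for antiproliferative activity, read by MTT assay, with a stated time of 48 h, in the presence of a further agent that is not named here; on this read-out lower numbers stand for stronger inhibition of growth and higher numbers for weaker inhibition of growth:
compound 1 `O=C(NOCc1ccccc1)c1cn(-c2ccccc2)nc1-c1ccccc1` gives 13400 nM
compound 2 `O=C(NOCc1ccccc1F)c1cn(-c2ccccc2)nc1-c1ccccc1` gives 16100 nM
compound 3 `O=C(NOCc1ccccc1Cl)c1cn(-c2ccccc2)nc1-c1ccccc1` gives 7410 nM

Compound 1 sits second highest of the three numbers in this assay. Its nearest neighbour is compound 2, at a 1.2-fold higher number from compound 1 to compound 2 (0.08 log units; within the scatter), and its furthest is compound 3, at a 1.8-fold lower number from compound 1 to compound 3 (0.26 log units; within the scatter); both steps lie within the scatter, so the three measured compounds are not separated beyond it, apart from the modest 2.2-fold lower number from compound 2 to compound 3 (0.34 log units; beyond the scatter).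

Compound 4 `O=C(NOCc1ccccc1)c1cn(-c2ccccc2)nc1-c1ccc(F)cc1` differs from compound 1 by fluoro in place of hydrogen on an aromatic carbon; read one bond further out, phenyl becomes 4-fluorophenyl, on the ring attached to the core rather than on the benzyl group.

Going by the values given here, the only measured step with the same change is a 1.2-fold higher number from compound 1 to compound 2 (0.08 log units; within the scatter), where fluoro entered the benzyl ring and stayed within the scatter. Among the compounds with values here, no measured compound carries a substituent on the ring changed here, so that step is the only guide. On this basis the step for compound 4 is expected to be a 1.0-fold lower number from compound 1 to compound 4 (0.01 log units; within the scatter), with no change beyond the scatter. Compound 4 is therefore estimated at 13000 nM, within 5000 nM to 32000 nM.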

Compound 4, concentration for 50% growth inhibition: 15300 nM
For compound 4 the middle estimate is 1.2-fold (0.07 log units) below the measured one; the range from low to high includes it.
By their numbers in this assay, from the lowest: compounds 3, 1, 4 and 2 (each within the scatter of the next, the first and the last beyond it).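

In this assay, fluoro on the phenyl ring attached to the core, giving a 4-fluorophenyl group, produces no change that can be separated from the scatter (a 1.1-fold higher number from compound 1 to compound 4 (0.06 log units; within the scatter)). Going by these compounds alone, this is the first reading for a substituent on this ring, so this position tolerates the exchange of hydrogen for fluoro at least as far as this growth read-out can show. Together with the same exchange on the benzyl ring (a 1.2-fold higher number from compound 1 to compound 2 (0.08 log units; within the scatter)), it gives two places where fluoro leaves compound 1 essentially unmoved, and no evidence bears on the reason for this result.

The compounds shown leave open whether this ring responds to anything larger or different in kind, such as chloro, which on the benzyl ring gave (a 1.8-fold lower number from compound 1 to compound 3 (0.26 log units; within the scatter)), or an amine or a carboxylic acid in the same place. As far as these compounds go, it also stays open whether fluoro would behave the same way on the other phenyl ring of the shared core.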